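A shorter arm on compound 3

This account rests on a few compounds, and the source may have more. Where it says the series, first, only, none or still open, it means among the compounds named here.

Of the compounds shown here, three sharing one core have been measured in an assay on Sf9 cells for inhibition of histone deacetylase 11 (Homo sapiens), read by fluorescence, tested at 0.5 uM; on this read-out lower numbers stand for less inhibition and higher numbers for more inhibition at the one concentration tested (going by the name of the read-out). Compound 3, `O=C(NO)c1ccc(-c2cn([C@H]3C[C@H](C(=O)O)N(CCCc4ccccc4)C3)nn2)cc1`, reaches only the limit of this assay, < 10%, so no number is known for it. Compound 1, `O=C(NO)c1ccc(-c2cn([C@@H]3C[C@H](C(=O)O)N(CCCc4ccccc4)C3)nn2)cc1`, likewise stops at the limit, with < 10%. Compound 2, `O=C(NO)c1ccc(-c2cn([C@H]3C[C@H](CO)N(CCCc4ccccc4)C3)nn2)cc1`, gives 18%. The step that the two limits leave unreadable from compound 1 to compound 3 cannot be sized because of the limit of < 10% in this assay, at which 2 of the 3 values shown sit, although the fact that compounds 1 and 3 differ only in the configuration as drawn makes it a clean comparison. The step of a number at least 8 percentage points lower from compound 2 to compound 3 (that floor lies within the scatter) is small.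

Compound 4, `O=C(/C=C/c1cn([C@H]2C[C@H](C(=O)O)N(CCCc3ccccc3)C2)nn1)NO`, is not yet measured. It differs from compound 3 in one place: 2-(hydroxycarbamoyl)ethenyl in place of 4-(hydroxycarbamoyl)phenyl on an aromatic carbon. Neither measured step touches this part of the molecule: one is unreadable and the other lies within the scatter, so they give no pointer toward a larger or a smaller number. The measured values show no strong inhibition anywhere in this set, so a step beyond the scatter in this assay is not expected. For compound 4 the estimated value in this assay is 10%, with a range from 0% to 25%. The expected step of a number no lower from compound 3 to compound 4 (the limit leaves the size open) therefore stays within the scatter.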

Compound 4, a percentage reported as inhibition, at one concentration (the size of the read-out at that concentration, not a potency): 20%
For compound 4 the middle estimate is 10 percentage points below the measured one; low and high end bracket the measured number.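

In this assay, placing 2-(hydroxycarbamoyl)ethenyl instead of 4-(hydroxycarbamoyl)phenyl on this aromatic carbon gives a number at least 10 percentage points higher from compound 3 to compound 4 (that floor lies within the scatter). Compound 3 gives < 10%, which is a limit and not a number, and only a floor can be read for the step because of this constraint: the limit of < 10% in this assay, at which 2 of the 4 values shown sit. What is new is that an arm with no ring at this position gives a readable result, as compound 4 reaches 20%, although this reflects inhibition at a single concentration and is not a potency.

The compounds shown leave open whether a saturated 2-(hydroxycarbamoyl)ethyl arm, or a longer chain ending in the same hydroxycarbamoyl group, would give a similar reading on this aromatic carbon. Going by these compounds alone, they also leave open how the 2-(hydroxycarbamoyl)ethenyl arm would read with a hydroxymethyl group in place of the carboxy group on the saturated ring carbon, the one place where compound 2 differs from compound 3.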